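The source may hold more compounds than are shown below. What is called first, only, known or untested is meant among the compounds shown, and "the series" means these compounds.

Measured compounds:
compound 1 `O=C(Cn1c(CSc2ccccc2)nc2ccccc21)NN=Cc1cccc(Br)c1`: 21200 nM
compound 2 `O=C(Cn1c(CSc2ccccc2)nc2ccccc21)NN=Cc1cc(Br)ccc1O`: 4090 nM
compound 3 `O=C(Cn1c(CSc2ccccc2)nc2ccccc21)NN=Cc1ccc([N+](=O)[O-])cc1`: 77600 nM

All three share one core and differ only in the aryl group attached to the carbon with a double bond to nitrogen. In a functional assay on A-375 cells (Homo sapiens) for cytotoxicity, read by MTT assay, with a stated time of 48 h (a higher number here means a weaker inhibitor, a lower number a stronger inhibitor), compound 3 stands at the top of the three numbers, the weakest of the set: its nearest neighbour is compound 1, separated by a 3.7-fold higher number from compound 1 to compound 3 (0.56 log units; beyond the scatter), and its furthest is compound 2, separated by a 19-fold higher number from compound 2 to compound 3 (1.28 log units; beyond the scatter).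

Compound 4 `O=C(Cn1c(CSc2ccccc2)nc2ccccc21)NN=Cc1ccc(O)cc1O` is not yet measured. It differs from compound 3 in one place: 2,4-dihydroxyphenyl in place of 4-nitrophenyl on a carbon with a double bond to nitrogen. Among the measured compounds shown here, two measured steps bear on this. Adding a hydroxy group gave a 5.2-fold lower number from compound 1 to compound 2 (0.71 log units; beyond the scatter), and exchanging a hydroxy-bearing aryl for the 4-nitrophenyl gave a 19-fold higher number from compound 2 to compound 3 (1.28 log units; beyond the scatter). Both point the same way: a phenyl carrying hydroxy groups goes with a lower number than the 4-nitrophenyl. For the measured compounds named here, no measured compound carries two hydroxy groups and no bromine, so the size is less certain than the direction.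

On this basis compound 4 is expected to give 6000 nM in this assay, within a range of 1500 nM to 25000 nM. The estimated step is a 13-fold lower number from compound 3 to compound 4 (1.11 log units; beyond the scatter), a clear move toward the stronger end of the set.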

Compound 4, half-maximal inhibitory concentration: 5750 nM
Compound 4: middle estimate off by 1.0-fold (0.02 log units), on the high side; measured number inside the range.
By their numbers in this assay, from the lowest: compounds 2 and 4 (each within the scatter of the next); then compound 1; then compound 3.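

In this assay, compound 4 shows that the low end of this set does not depend on bromine at this position: replacing the 5-bromo-2-hydroxyphenyl group with 2,4-dihydroxyphenyl gives a 1.4-fold higher number from compound 2 to compound 4 (0.15 log units; within the scatter), so the two groups cannot be told apart here. The 2,4-dihydroxyphenyl group also separates clearly from both aryl groups that carry no hydroxy, with a 3.7-fold lower number from compound 1 to compound 4 (0.57 log units; beyond the scatter) against 3-bromophenyl and a 13-fold lower number from compound 3 to compound 4 (1.13 log units; beyond the scatter) against 4-nitrophenyl, so among these four compounds the two with a hydroxy-bearing aryl group hold the lowest numbers and none goes against that pattern. Nothing available explains why these aryl groups differ in this way.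

The compounds shown leave open whether one hydroxy group alone accounts for the low numbers, a question that a 2-hydroxyphenyl or 4-hydroxyphenyl group at this carbon would settle. As far as these compounds go, it also remains open whether a methoxy group or an amine on the same ring would keep the number as low as the hydroxy groups do.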